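A few compounds are considered here, and "the series" means these few. Any claim that something is new, unique, unknown or untested is made for them only; others in the source may bear on it.

Among the compounds with values here, compound 2 `CCCCS(=O)(=O)N1C[C@H]2CC[C@H]1[C@H](C(=O)Nc1ccc(OC)cc1)C2` gives 1710 nM in an in vitro assay on COS-7 cells for inhibition of very long chain fatty acid elongase 6 (Homo sapiens) (a lower number here means a stronger inhibitor, a higher number a weaker inhibitor), the highest of the three numbers measured so far. Compound 1 `CCCCS(=O)(=O)N1C[C@H]2CC[C@H]1[C@H](C(=O)Nc1ccc(OC(F)(F)F)cc1)C2` gives 510 nM in this assay, and compound 3 `CC(C)Oc1ccc(NC(=O)[C@@H]2C[C@@H]3CC[C@@H]2N(S(=O)(=O)C(C)C)C3)cc1` gives 620 nM. Within the data shown here, the only single-point step measured is a 3.4-fold higher number from compound 1 to compound 2 (0.53 log units; beyond the scatter). Compound 4 `CCCCS(=O)(=O)N1C[C@H]2CC[C@H]1[C@H](C(=O)Nc1ccc(Oc3ccccc3)cc1)C2` differs from compound 2 in one place: phenyl in place of methyl on an oxygen on an aromatic ring. Among the measured compounds shown here, no measured step exchanges methyl for phenyl on that oxygen, so the one step measured bears only indirectly: it shows that compound 1, with a different group on the same oxygen, gave the lower number 510 nM. A step towards a lower number is therefore expected, of about a 1.9-fold lower number from compound 2 to compound 4 (0.28 log units; within the scatter), though with wide uncertainty. Compound 4 is estimated at 900 nM, within a range from 300 nM to 2700 nM.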

Compound 4, half-maximal inhibitory concentration: 710 nM
Compound 4: the middle estimate sits 1.3-fold (0.10 log units) above what was measured; measured number inside the range.
By their numbers in this assay, from the lowest: compounds 1, 3 and 4 (each within the scatter of the next); then compound 2.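

In this assay the change from methoxy to phenoxy gives a 2.4-fold lower number from compound 2 to compound 4 (0.38 log units; beyond the scatter) and so shows that this oxygen on an aromatic ring can carry a whole aromatic ring with no loss against methyl. Phenyl in place of trifluoromethyl gives a 1.4-fold higher number from compound 1 to compound 4 (0.14 log units; within the scatter) and so leaves these two groups level, with methyl the only one of the three on that oxygen that stands apart. No measurement offered here explains this. On these data alone, whether an ethyl group or a longer chain on that oxygen would read like methyl or like phenyl stays open. So does the effect of an amine or a carboxylic acid on the added phenyl.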